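This account rests on a few compounds, and the source may have more. Where it says the series, first, only, none or still open, it means among the compounds named here.

In a functional assay on HeLa cells (Homo sapiens) for antiproliferative activity, read by MTT assay, with a stated time of 48 h (on this read-out lower numbers stand for stronger inhibition of growth and higher numbers for weaker inhibition of growth), compound 1 `CCOC(=O)N1N=C(c2cccc(OC)c2)CC1c1cc(OC)c(OC)c(OC)c1` gives 4110 nM. Compound 2 `CCCOC(=O)N1N=C(c2cccc(OC)c2)CC1c1cc(OC)c(OC)c(OC)c1` reaches only a limit of the assay, > 10000 nM. Compound 3 `COc1cccc(C2=NN(C(=O)OCc3ccccc3)C(c3cc(OC)c(OC)c(OC)c3)C2)c1` is likewise known only as a limit, > 10000 nM. It therefore stands among the least informative points of this small set, which is dominated by the limit of > 10000 nM in this assay, at which 2 of the 3 values shown sit.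

Compound 4 `COc1ccc(C2=NN(C(=O)OCc3ccccc3)C(c3cc(OC)c(OC)c(OC)c3)C2)cc1` has the same atoms as compound 3, joined differently, with 4-methoxyphenyl in place of 3-methoxyphenyl on a carbon with a double bond to nitrogen. Going by the values given here, no measured step makes this swap. All of them alter the group on the oxygen next to the carbonyl group, so they bear on it only indirectly. Those steps are an at least 2.4-fold higher number from compound 1 to compound 2 (0.38 log units; beyond the scatter) and an at least 2.4-fold higher number from compound 1 to compound 3 (0.38 log units; beyond the scatter), while a step that the two limits leave unreadable from compound 2 to compound 3. Compound 4 keeps the benzyloxycarbonyl group of compound 3, and weak growth inhibition is expected here too because compound 3 stands at the limit > 10000 nM. Among the compounds with values here, a move of the methoxy group has no measured precedent, so no clear shift in either direction is expected, and a further limit is quite possible. The expected step is a number no higher from compound 3 to compound 4 (the limit leaves the size open). For compound 4 the estimate is 10000 nM, with an expected range from 3000 nM to 30000 nM.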

Compound 4, concentration for 50% growth inhibition: > 10000 nM
Compound 4 ended at the assay's limit; the forecaster's own chance of this, stated with the estimate: 60%; the middle value sits exactly at the limit.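

Compound 3 and compound 4 are both known only as limits of the assay, so the step between them cannot be read. The compounds shown leave open whether 4-methoxyphenyl in place of 3-methoxyphenyl changes growth inhibition at all, and the set remains dominated by a single ceiling: the limit of > 10000 nM in this assay, at which 3 of the 4 values shown sit.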